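A few compounds are considered here, and "the series" means these few. Any claim that something is new, unique, unknown or untested is made for them only; others in the source may bear on it.

Compound 3 `C=CC(=O)Nc1cc(Nc2nccc(-c3cn(C)c4ccc(F)cc34)n2)c(OC)cc1N(C)CCN(C)C` gives the lowest number of the three in a functional assay on NCI-H1975 cells (Homo sapiens) for antiproliferative activity, read by MTT assay, with a stated time of 72 h (a higher number here means a weaker inhibitor, a lower number a stronger inhibitor), at 254 nM. Compound 1 `C=C(Cl)C(=O)Nc1cc(Nc2nccc(-c3cn(C)c4ccccc34)n2)c(OC)cc1N(C)CCN(C)C` gives 1290 nM there and compound 2 `COc1cc(N(C)CCN(C)C)c(NC(=O)/C=C\C(C)C)cc1Nc1nccc(-c2cn(C)c3ccccc23)n1` gives 1820 nM. Compound 4 `CCC/C=C\C(=O)Nc1cc(Nc2nccc(-c3cn(C)c4ccc(F)cc34)n2)c(OC)cc1N(C)CCN(C)C` differs from compound 3 by pent-1-en-1-yl in place of vinyl on a carbonyl carbon. Within the data shown here, the one measured step that bears on this, a 1.4-fold higher number from compound 1 to compound 2 (0.15 log units; within the scatter), exchanged one substituted alkenyl for another on the same carbonyl carbon and stayed within the scatter. Compound 2, which also carries a branched alkenyl on that carbonyl, sits well above compound 3, but the two differ in more than one place. For compound 4 a rise of about a 2.6-fold higher number from compound 3 to compound 4 (0.41 log units; beyond the scatter) is expected, taking it to an estimated 650 nM, in the range 250 nM to 1800 nM.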

Compound 4, half-maximal inhibitory concentration: 2730 nM
Estimate against measurement, compound 4: 4.2-fold (0.62 log units) below; the measured number lies above the stated range.
By their numbers in this assay, from the lowest: compound 3; then compounds 1, 2 and 4 (each within the scatter of the next, the first and the last beyond it).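

On the carbonyl carbon bound to the amide-type nitrogen, pent-1-en-1-yl in place of vinyl gives an 11-fold higher number from compound 3 to compound 4 (1.03 log units; beyond the scatter) in this assay, so with the rest of the structure unchanged, this position does not accept the longer alkenyl without a large loss. The earlier step, a 1.4-fold higher number from compound 1 to compound 2 (0.15 log units; within the scatter), exchanged one substituted alkenyl for another, whereas this one measures a substituted alkenyl directly against plain vinyl. No data on hand give a reason for the size of this step. From the compounds shown here alone, it remains open whether a shorter prop-1-en-1-yl or an alkenyl chain ending in a dimethylamine on this carbonyl carbon would stay close to compound 3.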